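The source may hold more compounds than are shown below. What is called first, only, known or untested is meant among the compounds shown, and "the series" means these compounds.

In a functional assay on K562 cells (Homo sapiens) for cytotoxicity, read by trypan blue exclusion, with a stated time of 96 h (on this read-out lower numbers stand for stronger inhibition and higher numbers for weaker inhibition), compound 1 `COc1ccc(CS(=O)(=O)/C=C/c2c(F)cc(F)cc2F)cc1N` gives 800 nM. Compound 2 `COC(=O)C(C)(C)Nc1cc(CS(=O)(=O)/C=C/c2c(OC)cc(OC)cc2OC)ccc1OC`, which shares the trimethoxyphenyl-bearing core with the new compound, gives 800 nM in this assay, so the two measured values stand level with one another, within the scatter of repeated runs. Among the measured compounds shown here, no step between measured compounds that differ in one place has been recorded, so there is nothing to calibrate the next change against. Compound 3 `COc1cc(OC)c(/C=C/S(=O)(=O)Cc2ccc(OC)c(NC(C(=O)O)c3ccc(Br)cc3)c2)c(OC)c1` differs from compound 2 by (4-bromophenyl)(carboxy)methyl in place of 1-(methoxycarbonyl)-1-methylethyl on a nitrogen on an aromatic ring. For the measured compounds named here, with no measured precedent for this exchange, the step from compound 2 to compound 3 is expected to be modest, on the side of weaker inhibition, at about a 1.9-fold higher number from compound 2 to compound 3 (0.27 log units; within the scatter). Compound 3 is therefore estimated to give 1500 nM in this assay, with a plausible range from 500 nM to 5000 nM, the true value being unknown until measured.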

Compound 3, half-maximal inhibitory concentration: 200 nM
Beside the measured number, compound 3's estimate is 7.5-fold (0.88 log units) above it, outside the stated range (below it).
By their numbers in this assay, from the lowest: compound 3; then compounds 1 and 2 (each within the scatter of the next).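

In this assay, among the compounds shown here, the group on a nitrogen on an aromatic ring proves open to a large exchange: (4-bromophenyl)(carboxy)methyl in place of 1-(methoxycarbonyl)-1-methylethyl gives a 4.0-fold lower number from compound 2 to compound 3 (0.60 log units; beyond the scatter) and is the only step here between compounds that differ in one place. It shows that this position accepts the larger group, which brings an aromatic ring and a free carboxylic acid, and that the number moves towards stronger inhibition, which the earlier level values could not show. Nothing measured here accounts for the step.

Going by these compounds, the exchange alters several features at once, so it remains open which of them carries the step. A methyl ester in place of the carboxylic acid, or a plain phenyl in place of 4-bromophenyl, would begin to separate them.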